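From methylsulfanyl to methylamino on the shared core

The source may hold more compounds than are shown below. What is called first, only, known or untested is meant among the compounds shown, and "the series" means these compounds.

In a functional assay on HepG2 cells (Homo sapiens) for antiproliferative activity, read by XTT assay, with a stated time of 72 h (a lower number here means a stronger inhibitor, a higher number a weaker inhibitor), compound 1 `CSc1ncnc2c1c(-c1ccoc1)cn2[C@@H]1O[C@H](CO)[C@@H](O)[C@H]1O` gives > 15000 nM, which is a limit. Compound 2 `CSc1ncnc2c1c(-c1cccs1)cn2[C@@H]1O[C@H](CO)[C@@H](O)[C@H]1O` gives > 20000 nM, also a limit. Compound 3 `C#Cc1cn([C@@H]2O[C@H](CO)[C@@H](O)[C@H]2O)c2ncnc(SC)c12` gives > 15000 nM, again a limit. Compound 4 `CNc1ncnc2c1c(-c1ccoc1)cn2[C@@H]1O[C@H](CO)[C@@H](O)[C@H]1O` carries methylamino in place of methylsulfanyl on an aromatic carbon. The measured steps are a step that the two limits leave unreadable from compound 1 to compound 2, a step that the two limits leave unreadable from compound 1 to compound 3 and a step that the two limits leave unreadable from compound 2 to compound 3. All three keep methylsulfanyl, so none sizes this change. The expectation therefore rests on compound 1 at > 15000 nM, a limit, and only leans towards stronger inhibition. The expected step is an at least 3.0-fold lower number from compound 1 to compound 4 (0.47 log units; beyond the scatter), and its size is poorly fixed. Compound 4 is estimated at 5000 nM, with an expected range of 300 nM to 20000 nM.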

Compound 4, half-maximal inhibitory concentration: > 20000 nM
Compound 4 gave a limit, no number; the forecaster's own chance of this, stated with the estimate: 45%; middle value at least 4.0-fold (0.60 log units) away from the limit.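

Compound 1 and compound 4 both stand as limits, and the step between them cannot be read. The compounds shown leave open whether methylamino in place of methylsulfanyl changes activity at all: none has a measured number.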